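The source may hold more compounds than are shown below. What is called first, only, known or untested is meant among the compounds shown, and "the series" means these compounds.

Compound 1 `O=S(=O)(c1ccc(F)c(Cl)c1)c1cnc2cc(F)ccc2c1-c1ccc(Cl)cc1`: 8.3 nM in an assay (strain Sprague-Dawley) for displacement of a labelled ligand from metabotropic glutamate receptor 5 (Rattus norvegicus), with a stated time of 60 min; on this read-out higher numbers stand for weaker inhibition and lower numbers for stronger inhibition
Compound 2 `O=S(=O)(c1cc(Cl)cc(Cl)c1)c1cnc2cc(F)ccc2c1-c1ccc(Cl)cc1`: 30.3 nM

Among the measured compounds shown here, compound 2 gives the highest of the two numbers in this assay; the only other compound measured, compound 1, gives a lower one. For the measured compounds named here, the single step that bears on the question is a 3.7-fold higher number from compound 1 to compound 2 (0.56 log units; beyond the scatter), modest but beyond the scatter. Compound 3 `O=S(=O)(c1ccc(F)c(F)c1)c1cnc2cc(F)ccc2c1-c1ccc(Cl)cc1` differs from compound 2 in one place: 3,4-difluorophenyl in place of 3,5-dichlorophenyl on a sulfonyl sulfur. Since the 3-chloro-4-fluorophenyl of compound 1 and the incoming 3,4-difluorophenyl are alike in their halogen pattern, a return toward the number of compound 1 is expected, a step of a 2.5-fold lower number from compound 2 to compound 3 (0.40 log units; beyond the scatter). Compound 3 is therefore expected to give about 12 nM, within a range from 4 nM to 36 nM.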

Compound 3, inhibition constant: 17.1 nM
The estimate for compound 3 lay 1.4-fold (0.15 log units) below the measured number, and the stated range covers the measured number.
By their numbers in this assay, from the lowest: compound 1; then compounds 3 and 2 (each within the scatter of the next).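

In this assay the exchange of 3,5-dichlorophenyl for 3,4-difluorophenyl on a sulfonyl sulfur gives a 1.8-fold lower number from compound 2 to compound 3 (0.25 log units; within the scatter) and so does not separate these two halogen patterns. Fluoro in place of chloro on an aromatic carbon gives a 2.1-fold higher number from compound 1 to compound 3 (0.31 log units; beyond the scatter) and is the only step shown that changes a single halogen on this ring, with a modest effect on the number. Nothing available here accounts for either step.

The compounds shown leave open how an unsubstituted phenyl would read on the sulfonyl sulfur. They also leave open how a phenyl bearing a methoxy or an amine would read there.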